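A few compounds are considered here, and "the series" means these few. Any claim that something is new, unique, unknown or untested is made for them only; others in the source may bear on it.

Measured so far in a functional assay on HCT-116 cells (Homo sapiens) for antiproliferative activity; on this read-out lower numbers stand for stronger inhibition and higher numbers for weaker inhibition:
- Compound 1 `Cc1c2c(n3c1CCN(C(=O)CN)C[C@@H](C)[C@H](C)Nc1cc-3ccc1C(N)=O)CC(C)(C)CC2=O`: 216 nM
- Compound 2 `CC[C@H](N)C(=O)N1CCc2c(C)c3c(n2-c2ccc(C(N)=O)c(c2)N[C@@H](C)[C@H](C)C1)CC(C)(C)CC3=O`: 33 nM

Of these two compounds, compound 2 has the lower number, 33 nM, while compound 1 reads 216 nM. Within the data shown here, only one measured step bears on what follows: a 6.5-fold lower number from compound 1 to compound 2 (0.82 log units; beyond the scatter). That step put ethyl in place of hydrogen on a saturated chain carbon bound to an amine nitrogen and a carbonyl carbon, so it shows that a change in this part of the molecule can move the number well beyond the scatter.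

The next compound is compound 3 `Cc1c2c(n3c1CCN(C(=O)C1(N)CC1)C[C@@H](C)[C@H](C)Nc1cc-3ccc1C(N)=O)CC(C)(C)CC2=O`. Its change from compound 2 is 1-aminocyclopropyl in place of 1-aminopropyl on a carbonyl carbon, which in words is 1-aminocyclopropyl in place of 1-aminopropyl on a carbonyl carbon. Among the measured compounds shown here, no measured compound yet carries a ring in this place, so the direction is a cautious judgement. A compound 2 that is the better of only two gives more room upward than downward, and a smaller shift than the measured one seems likely. The expected change is a 2.3-fold higher number from compound 2 to compound 3 (0.36 log units; beyond the scatter). For compound 3 the estimated value is 75 nM, with an expected range of 25 nM to 220 nM.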

Compound 3, half-maximal inhibitory concentration: 81 nM
For compound 3 the middle estimate is 1.1-fold (0.03 log units) below the measured one, within the range that was stated.
By their numbers in this assay, from the lowest: compound 2; then compound 3; then compound 1.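

In this assay, tying the side group back into a ring gives a weaker result than the open chain (a 2.5-fold higher number from compound 2 to compound 3 (0.39 log units; beyond the scatter)), even though 1-aminocyclopropyl and 1-aminopropyl have the same counts of heavy atoms, donors and acceptors. So this position responds to the shape of the group on the carbonyl carbon, and not only to which atoms it contains. The ring still improves on the plain aminomethyl group (a 2.7-fold lower number from compound 1 to compound 3 (0.43 log units; beyond the scatter)), which places it in the middle of the three compounds, with every gap between them beyond the scatter, and no supporting data are available to explain this order.

These compounds cannot separate the effect of the ring itself from the disappearance of the defined stereocentre, as the 1-aminocyclopropyl group has none and the 1-aminopropyl group has one. Also open, on these data alone, is where this assay would place a 1-aminocyclobutyl group, a longer chain such as 1-aminobutyl, or a dimethylamino group in place of the free amine on this same carbonyl carbon.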